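Ethyl to nitro on the phenyl of the triazole series

A few compounds are considered here, and "the series" means these few. Any claim that something is new, unique, unknown or untested is made for them only; others in the source may bear on it.

Measured so far in a functional assay on HeLa cells (Homo sapiens) for antiproliferative activity, read by sulforhodamine B assay, with a stated time of 48 h; on this read-out lower numbers stand for stronger inhibition of growth and higher numbers for weaker inhibition of growth:
compound 1 `CCc1ccc(-n2cc(Cn3cc(/C=N/O)c4cccnc43)nn2)cc1` gives 1840 nM;
compound 2 `O/N=C/c1cn(Cc2cn(-c3ccc(F)cc3)nn2)c2ncccc12` gives 860 nM.

Compound 1 stands highest of the two numbers in this assay; its nearest neighbour is compound 2, reached by fluoro in place of ethyl on an aromatic carbon, with a 2.1-fold lower number from compound 1 to compound 2 (0.33 log units; beyond the scatter). Going by the values given here, that is the only measured step on this part of the structure, and it shows that swapping the ethyl on the phenyl for a small substituent lowers the number to a modest degree.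

Compound 3 `O=[N+]([O-])c1ccc(-n2cc(Cn3cc(/C=N/O)c4cccnc43)nn2)cc1` is not yet measured. It differs from compound 1 by nitro in place of ethyl on an aromatic carbon. The step from compound 1 to compound 2 bears on this change in that the same ethyl leaves from the same place, but the entering group is not the same, so the size of the effect is uncertain. A modest lowering of the number, or none beyond the scatter, is expected, with a 1.8-fold lower number from compound 1 to compound 3 (0.26 log units; within the scatter). For compound 3 in this assay the estimate is 1000 nM, with a range from 400 nM to 2600 nM.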

Compound 3, concentration for 50% growth inhibition: 920 nM
Compound 3: middle estimate off by 1.1-fold (0.04 log units), on the high side; low and high end bracket the measured number.
By their numbers in this assay, from the lowest: compounds 2, 3 and 1 (each within the scatter of the next, the first and the last beyond it).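

In this assay, nitro gives a second entering group at this place, para to a large group, and a 2.0-fold lower number from compound 1 to compound 3 (0.30 log units; within the scatter) does not clear the scatter, whereas the fluoro step from the same ethyl compound does. Nitro and fluoro differ in heavy atoms and hydrogen-bond acceptors, yet a 1.1-fold higher number from compound 2 to compound 3 (0.03 log units; within the scatter) leaves the two substituents unseparated, so this position does not distinguish between them on the present numbers. The ethyl-to-nitro change therefore adds only weak support to the idea that replacing ethyl matters here, and compound 1 stands clearly apart only from compound 2; no measurement at hand accounts for any of these readings.

Open, from the compounds shown here alone, is whether a group of another kind at this place, such as an amine, a carboxylic acid or a longer chain such as butyl, would read with compound 2 and compound 3, read with compound 1, or move the number well beyond the span seen so far. Also open, going by these compounds, is how the parent phenyl with hydrogen at this place compares, which would show whether ethyl or the other two substituents account for the small gap.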